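The compounds below may be only part of what the source reports. "The series", "measured", "known", "first", "only" and "open" are said of these compounds alone.

Compound 3, with the structure `O=c1ncn(Cc2c(F)cc(F)cc2F)c2ccc(Oc3cccc(-c4ccc5cc[nH]c5c4)c3C(F)(F)F)cc12`, has in an ADME assay on Caco-2 cells (Homo sapiens) for permeability, in the apical to basolateral direction (a lower number here means that the compound crosses the layer more slowly, a higher number that the compound crosses the layer faster), only the entry "not determined" (no result reported), so where it stands can only be judged from its neighbours. Compound 2, with the structure `O=c1ncn(Cc2c(F)cc(F)cc2F)c2ccc(Oc3cccc(-c4ccc5[nH]ccc5c4)c3C(F)(F)F)cc12`, differs from compound 3 only in the point where the five-membered ring of the indolyl group is joined, and in this assay compound 2 gives 10.5 10^-6 cm/s. Compound 1, with the structure `O=C(Nc1ccccc1)c1cccc(Oc2ccc3c(c2)c(=O)ncn3Cc2c(F)cc(F)cc2F)c1C(F)(F)F`, carries a phenylcarbamoyl group in that position instead, and in this assay compound 1 gives 0.84 10^-6 cm/s. Among the measured compounds shown here, the one measured step, a 13-fold higher number from compound 1 to compound 2 (1.10 log units; beyond the scatter), shows that exchanging the group at this position can move the number a great deal.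

Compound 4, with the structure `Nc1ccc(-c2cccc(Oc3ccc4c(c3)c(=O)ncn4Cc3c(F)cc(F)cc3F)c2C(F)(F)F)cn1`, arises from compound 3 by the change (6-aminopyridin-3-yl in place of 1H-indol-6-yl on an aromatic carbon). For the measured compounds named here, no measured step covers this particular exchange, and compound 3 itself supplies no starting number. Because a 13-fold higher number from compound 1 to compound 2 (1.10 log units; beyond the scatter) shows that the indolyl group sits at the high end of what has been seen, while the amide-bearing group of compound 1 sits at the low end, the 6-aminopyridin-3-yl group is expected to land in between, with wide uncertainty. Compound 4 is therefore estimated at 3 10^-6 cm/s, within a range of 0.8 10^-6 cm/s to 9 10^-6 cm/s.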

Compound 4, apparent permeability: 4.1 10^-6 cm/s
Compound 4: middle estimate off by 1.4-fold (0.14 log units), on the low side; measured number inside the range.
By their numbers in this assay, from the lowest: compound 1; then compound 4; then compound 2.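

In this assay, the position ortho to the trifluoromethyl group now has a third reading, and it falls clearly apart from both earlier ones. Placing 6-aminopyridin-3-yl there gives a 2.6-fold lower number from compound 2 to compound 4 (0.41 log units; beyond the scatter) and also a 4.9-fold higher number from compound 1 to compound 4 (0.69 log units; beyond the scatter), so the three groups spread out in order rather than forming just a high and a low case, and a single six-membered aromatic ring with an amino group can keep the number well clear of the phenylcarbamoyl case without matching the 1H-indol-5-yl case. No measurement shown here explains why the number moves with these exchanges.

On these data alone, the direct exchange from 1H-indol-6-yl to 6-aminopyridin-3-yl cannot be read, since compound 3 has no number, and it therefore stays unknown whether the way the indolyl group is attached changes the result. As far as these compounds go, the 6-aminopyridin-3-yl group also differs from the indolyl groups in several features at once, so it remains open how a plain pyridin-3-yl group without the amine, or a phenyl group carrying the same amine, would compare at this position.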